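Amide-linked piperazines and piperidine at dopamine D4: Emax notes

This account rests on a few compounds, and the source may have more. Where it says the series, first, only, none or still open, it means among the compounds named here.

Measured so far:
compound 1 `O=C(CN1CCN(c2ccccn2)CC1)Nc1cccnc1` — 47.3%
compound 2 `Cc1cccc(NC(=O)CN2CCC(c3ccccc3)CC2)c1` — 32.9%
compound 3 `Cc1cccc(NC(=O)CCN2CCN(c3ncccn3)CC2)c1` — 13.7%

Three compounds carry a number in a functional assay on cells for agonist activity at D(4) dopamine receptor (Homo sapiens), read by TR-FRET and cAMP accumulation, with a stated time of 30 min; on this read-out higher numbers stand for larger maximal responses and lower numbers for smaller maximal responses. Compound 1 `O=C(CN1CCN(c2ccccn2)CC1)Nc1cccnc1` stands highest of the three; compound 2 `Cc1cccc(NC(=O)CN2CCC(c3ccccc3)CC2)c1` lies nearest to it, and the gap between compound 1 and compound 2 is beyond the scatter of this assay. Compound 3 `Cc1cccc(NC(=O)CCN2CCN(c3ncccn3)CC2)c1` lies furthest from compound 1, and that gap is also beyond the scatter. No pair among these three differs in a single place, so no step between measured compounds can be set out, and nothing is known from them about what happens when only the ring on the amide-type nitrogen is exchanged.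

The next compound, compound 4 `O=C(CN1CCN(c2ccccn2)CC1)Nc1cncnc1`, departs from compound 1 in one place: pyrimidin-5-yl in place of pyridin-3-yl on an amide-type nitrogen. The change keeps the rest of the molecule as in compound 1 and alters only the aromatic ring attached to the amide-type nitrogen.

Among the compounds with values here, with no comparable step among the measured compounds, the expected step from compound 1 to compound 4 in this assay is small and may not exceed the scatter: a number 6.3 percentage points lower from compound 1 to compound 4 (within the scatter). For compound 4 the maximal response in this assay is estimated at 41%, with a range from 22% to 58%, resting only on the value of compound 1 in this assay.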

Compound 4, largest response reached (Emax), in percent of the reference or control that the assay uses: "not active" (no number reported)
No number was reported for compound 4, so the estimate cannot be set against anything.
By their numbers in this assay, from the lowest: compound 3; then compound 2; then compound 1.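

In this assay, within the data shown here, compound 4 is reported as not active, with no number, so no step from compound 1 to compound 4 can be read. Nothing shown here bears on the cause of this result. The compounds shown leave open whether pyrimidin-5-yl in place of pyridin-3-yl would give the same outcome with any other amine portion.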